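This account rests on a few compounds, and the source may have more. Where it says the series, first, only, none or still open, it means among the compounds named here.

Compound 2, `Cc1cc(/C=C2\SC(=S)N(Cc3ccccc3C(F)(F)F)C2=O)c(C)n1-c1ccc(O)c(C(=O)O)c1`, and compound 1, `Cc1cc(/C=C2\SC(=S)N(Cc3ccc(C(C)(C)C)cc3)C2=O)c(C)n1-c1ccc(O)c(C(=O)O)c1`, share a core and differ only in the group carried on the saturated chain carbon bound to an amide-type nitrogen in a ring. In an ADME assay on MT2 cells (Homo sapiens) for cytotoxicity, read by XTT assay, with a stated time of 4 days (a higher number here means that more compound is tolerated, a lower number that less compound is tolerated), compound 1 gives 55200 nM, and compound 2 gives 28800 nM. Compound 2 thus stands at the low end of the two numbers shown, although a 1.9-fold lower number from compound 1 to compound 2 (0.28 log units; within the scatter), so the two cannot be told apart. Compound 3, `Cc1cc(/C=C2\SC(=S)N(Cc3ccccc3Br)C2=O)c(C)n1-c1ccc(O)c(C(=O)O)c1`, differs from compound 2 by bromo in place of trifluoromethyl on an aromatic carbon. Among the measured compounds shown here, only that single step bears on this change: it exchanged the whole aryl group on the same chain carbon, 2-(trifluoromethyl)phenyl in place of 4-(tert-butyl)phenyl, and still remained within the scatter. Compound 3 is therefore expected to show no step beyond the scatter, the estimated step being a 1.1-fold higher number from compound 2 to compound 3 (0.05 log units; within the scatter). Compound 3 is estimated at 32000 nM, within a range from 13000 nM to 80000 nM.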

Compound 3, half-maximal cytotoxic concentration: 25700 nM
The estimate for compound 3 lay 1.2-fold (0.10 log units) above the measured number; the measured number falls inside the stated range.
By their numbers in this assay, from the lowest: compounds 3, 2 and 1 (each within the scatter of the next, the first and the last beyond it).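

In this assay, bromo in place of trifluoromethyl on this aromatic carbon gives a 1.1-fold lower number from compound 2 to compound 3 (0.05 log units; within the scatter), so at this position, ortho to a large group, a single bromine atom and a trifluoromethyl group of 4 heavy atoms cannot be told apart. Among the compounds shown here, the wider exchange of the whole aryl group, 2-bromophenyl in place of 4-(tert-butyl)phenyl, gives a 2.1-fold lower number from compound 1 to compound 3 (0.33 log units; beyond the scatter), the first step here to pass the scatter, though only modestly, while compound 2 stays within the scatter of both others. From the compounds shown here alone, whether an amine or a carboxylic acid on the same aromatic carbon would shift the number remains open. So does the effect of a longer chain joining the aryl group to the amide-type nitrogen in the ring. Nothing measured here accounts for these numbers.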